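Adding a chloro group to compound 2

A few compounds are considered here, and "the series" means these few. Any claim that something is new, unique, unknown or untested is made for them only; others in the source may bear on it.

In an ADME assay on microsomes from liver (Homo sapiens) for metabolic stability, with a stated time of 10 min, tested at 0.5 uM (a lower number here means that less of the compound is left, a higher number that more of the compound is left), compound 1 (`CC(C)COc1ncc(-c2cn(C)c3cc(C(=O)NS(C)(=O)=O)ccc23)cc1Cl`) stands at 95% and compound 2 (`CC(C)COc1ccc(-c2cn(C)c3cc(C(=O)NS(C)(=O)=O)c(F)cc23)cn1`) stands at 98% so the two numbers lie within the scatter of each other. Both sit close to the top of the scale, and little of either compound is lost. Among the compounds with values here, no pair of measured compounds differs in one place only, so the series gives no direct measure of what a single change does.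

Compound 3 (`CC(C)COc1ncc(-c2cn(C)c3cc(C(=O)NS(C)(=O)=O)c(F)cc23)cc1Cl`) is compound 2 with chloro in place of hydrogen on an aromatic carbon of the six-membered aromatic ring with 1 nitrogen, ortho to an isobutoxy group and two atoms from the ring nitrogen. With compound 2 at 98% the scale leaves little room upward, so any shift is expected to be small and downward. The estimate is a number 5 percentage points lower from compound 2 to compound 3 (within the scatter) in this assay and this expected step stays within the scatter. For compound 3 the estimated value is 93% with an expected range from 82% to 100% on repeated measurement.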

Compound 3, percent of the compound remaining: 100%
For compound 3 the middle estimate is 7 percentage points below the measured one; the measured number falls inside the stated range.
By their numbers in this assay, from the lowest: compounds 1, 2 and 3 (each within the scatter of the next).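

In this assay the series now has two direct single-change readings, and both stay within the scatter. Chloro on an aromatic carbon of the six-membered aromatic ring with 1 nitrogen, ortho to an isobutoxy group, gives a number 2 percentage points higher from compound 2 to compound 3 (within the scatter) and so brings no measurable loss of compound at this place, while a fluoro group added to the shared core gives a number 5 percentage points higher from compound 1 to compound 3 (within the scatter) and reads the same way with the chloro already present. No available data bear on the reason for either step.

With compound 2 and compound 3 both at the top of the scale, this read-out cannot tell whether either substituent adds anything to stability, or whether a difference would appear with more of the compound lost. Also open, from the compounds shown here alone, is how far this tolerance extends: a nitrile, a methyl or an amine in place of the chloro, a longer chain in place of the isobutoxy group, or a carboxylic acid on the core could each behave differently.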